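Notes on chain extension and cytotoxicity

The compounds below may be only part of what the source reports. "The series", "measured", "known", "first", "only" and "open" are said of these compounds alone.

Measured compounds:
- compound 1 `CCCCCC#Cc1cc2cn(COCCO)c(=O)nc2o1`: >= 100000 nM
- compound 2 `OCCOCn1cc2ccnc-2nc1O`: > 400000 nM
- compound 3 `CCCCCc1cc2cn(COCCO)c(O)nc-2n1`: > 400000 nM

In a functional assay on HEL cells (Homo sapiens), read by microscopy (on this read-out higher numbers stand for lower toxicity in this test and lower numbers for higher toxicity in this test), compound 1 gives >= 100000 nM, which is a limit of the test and not a number. Compound 2 gives > 400000 nM, also a limit. Compound 3 gives > 400000 nM, again a limit. Compound 3 thus sits at the limit of > 400000 nM in this assay, at which 2 of the 3 values shown sit, as does compound 2, whereas compound 1 sits at the limit of >= 100000 nM in this assay, at which 1 of the 3 values shown sits. Going by the values given here, the single one-place step recorded, a step that the two limits leave unreadable from compound 2 to compound 3, has no readable size, since both ends are limits.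

Compound 4 `CCCCCCCCCCCc1cc2cn(COCCO)c(O)nc-2n1` differs from compound 3 by hexyl in place of hydrogen on a saturated chain carbon, five bonds along the chain from an aromatic carbon. Among the compounds with values here, no measured step bears directly on this change: the only step available, a step that the two limits leave unreadable from compound 2 to compound 3, is unreadable, and no measured compound carries a chain beyond pentyl. The data therefore give no direction beyond the scatter for the expected step of an at least 2.0-fold lower number from compound 3 to compound 4 (0.30 log units; that floor lies within the scatter). Compound 4 is estimated at 200000 nM, with a range from 50000 nM to 400000 nM, and a limit rather than a number is the more likely report.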

Compound 4, minimum cytotoxic concentration: 80000 nM
The estimate for compound 4 lay 2.5-fold (0.40 log units) above the measured number, and the stated range covers the measured number.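

In this assay, going by these compounds alone, hexyl in place of hydrogen on a saturated chain carbon, five bonds along the chain from an aromatic carbon, gives an at least 5.0-fold lower number from compound 3 to compound 4 (0.69 log units; beyond the scatter), the first readable step. Compound 3 gives > 400000 nM, which is a limit of the test and not a number. The end of the chain is thus a place where a change shows on this read-out, in the direction of higher toxicity in this test, while the step from hydrogen to pentyl on the aromatic carbon cannot be read.

The compounds shown leave open whether a heptyl or octyl chain on the aromatic carbon already gives a lower number, or whether a chain longer than that of compound 4 lowers it further. They also leave open whether an amine or a carboxylic acid at the end of the chain keeps or removes this step.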